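The source may report more compounds than this note shows. Statements on the series, on what has been measured and on what is new or still open speak of the compounds shown alone.

Of the compounds shown here, two of this set have been measured in a functional assay on BE(2)-C cells (Homo sapiens) for inhibition, read by MTT assay, with a stated time of 72 h; a higher number here means a weaker inhibitor of growth, a lower number a stronger inhibitor of growth. Compound 1 `O=S(=O)(NCCNCc1cccc2ccccc12)c1cc(C(F)(F)F)cc(C(F)(F)F)c1` gives 19000 nM in this assay. Compound 2 `CN(CCCNS(=O)(=O)c1cc(C(F)(F)F)cc(C(F)(F)F)c1)Cc1ccccc1` gives 28000 nM in this assay, the higher of the two numbers, although its nearest neighbour, compound 1, sits within the scatter of it, so the two cannot be told apart on these data.

Compound 3 `O=S(=O)(NCCCNCc1ccc(Cl)cc1)c1cc(C(F)(F)F)cc(C(F)(F)F)c1` has not yet been measured. It differs from compound 2 in one place: (4-chlorobenzyl)amino in place of benzyl(methyl)amino on a saturated chain carbon, three bonds along the chain from a sulfonamide nitrogen. For the measured compounds named here, no pair of measured compounds differs in exactly that place, so there is no measured step to lean on. Compound 1 differs from compound 2 in more than one place, and its value and that of compound 2 lie within the scatter of each other, which gives no sign that changes of this kind move the number far. The step is therefore expected to be small, not beyond the scatter, with at most a slight lean toward a lower number. The estimated step from compound 2 to compound 3 in this assay is a 1.4-fold lower number from compound 2 to compound 3 (0.15 log units; within the scatter). Compound 3 is expected to give 20000 nM in this assay, within a range from 8000 nM to 50000 nM.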

Compound 3, concentration for 50% growth inhibition: 2900 nM
The estimate for compound 3 lay 6.9-fold (0.84 log units) above the measured number; measured number below the stated range.
By their numbers in this assay, from the lowest: compound 3; then compounds 1 and 2 (each within the scatter of the next).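

In this assay, the swap of benzyl(methyl)amino for (4-chlorobenzyl)amino on a saturated chain carbon, three bonds along the chain from a sulfonamide nitrogen, gives a 9.7-fold lower number from compound 2 to compound 3 (0.98 log units; beyond the scatter), the first measured sign that a change at this place can move the number well past the scatter. The values of compound 1 and compound 2 could not show this, as they lie within the scatter of each other and differ in more than one place. This single swap changes two things together, since it adds a chlorine to the ring and replaces the methyl on the amine nitrogen with a hydrogen, and nothing available here explains why the number falls.

Going by these compounds, how the step divides between the chlorine and the loss of the methyl remains open, and a benzylamino group or a (4-chlorobenzyl)(methyl)amino group at the same place would separate the two. On these data alone, whether the (4-chlorobenzyl)amino group would act in the same way on the chain of compound 1 also remains open.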